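The source may report more compounds than this note shows. Statements on the series, on what has been measured and on what is new or still open speak of the compounds shown alone.

In a functional assay on HT-29 cells (Homo sapiens) for cytotoxicity, read by MTT assay, with a stated time of 48 h (on this read-out higher numbers stand for weaker inhibition and lower numbers for stronger inhibition), compound 1 `CCCCOC(=O)/C=C/c1ccc2c(c1)C(=O)C(=O)N2Cc1ccc(OC)cc1` gives 420 nM. Compound 3 `COC(=O)/C=C/c1ccc2c(c1)C(=O)C(=O)N2Cc1ccccc1` gives 70 nM, a lower number than that of compound 1, and the gap between them lies beyond the usual scatter. Compound 1 therefore holds the higher of the two actual numbers in this small set. For compound 2 `COC(=O)/C=C/c1ccc2c(c1)N(Cc1ccc(OC)cc1)C(=O)C2=O`, this assay reports only a limit, > 10000 nM, and not a number.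

The next compound to be tested, compound 4 `COc1ccc(CN2C(=O)C(=O)c3cc(/C=C/C(=O)OC(C)(C)C)ccc32)cc1`, differs from compound 1 only in the ester: tert-butyl in place of butyl on an oxygen next to a carbonyl group. The change places tert-butyl in place of butyl on an oxygen next to a carbonyl group, so the two compounds have the same atoms, joined differently.

Within the data shown here, no measured pair isolates this change, so any expectation is loose and starts from compound 1 at 420 nM. Among the measured compounds shown here, the numbers so far differ widely across small structural changes, which argues for a broad range. A modest move toward weaker inhibition is expected, and it may not clear the scatter, with the estimated step of a 1.7-fold higher number from compound 1 to compound 4 (0.22 log units; within the scatter). For compound 4 the estimated value is 700 nM, with an expected range from 150 nM to 3500 nM.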

Compound 4, half-maximal inhibitory concentration: 480 nM
Compound 4: middle estimate off by 1.5-fold (0.16 log units), on the high side, and the stated range covers the measured number.
By their numbers in this assay, from the lowest: compound 3; then compounds 1 and 4 (each within the scatter of the next). At a limit, above all of these: compound 2.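

In this assay, among these compounds, the ester of compound 1 gives the first readable step at a single position, a 1.1-fold higher number from compound 1 to compound 4 (0.06 log units; within the scatter). Among compounds 1, 2 and 3 no pair differs in one place alone, so those compounds could not show what a single change does. Compound 1 and compound 4 carry the same atoms, joined differently, and they read alike, so on the core of compound 1 tert-butyl serves on the oxygen next to a carbonyl group as well as butyl does in this cell assay.

On these data alone, whether that tolerance extends beyond these two butyl isomers stays open, for instance to a carboxylic acid in place of the ester or to a longer chain on the same oxygen, and a single pair cannot settle it. Nothing among the measurements shown offers an explanation for why these two esters read alike.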